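Replacing 2-chlorophenyl with 4-nitrophenyl: notes on compound 4

The source may report more compounds than this note shows. Statements on the series, on what has been measured and on what is new or still open speak of the compounds shown alone.

Of the compounds shown here, three sharing one core have been measured in a functional assay on MCF7 cells (Homo sapiens) for antiproliferative activity, read by MTT assay, with a stated time of 48 h; on this read-out lower numbers stand for stronger inhibition and higher numbers for weaker inhibition. Compound 1 `O=C(/C=C/c1ccc(O)c(O)c1)N1CCN(c2ccccc2F)CC1` gives 1.38 ug/mL, compound 2 `O=C(/C=C/c1ccc(O)c(O)c1)N1CCN(c2ccccc2Cl)CC1` gives 1.36 ug/mL and compound 3 `COc1ccccc1N1CCN(C(=O)/C=C/c2ccc(O)c(O)c2)CC1` gives 0.54 ug/mL. Compound 2 therefore belongs to the upper pair of the three numbers, and chloro in place of fluoro shows a 1.0-fold lower number from compound 1 to compound 2 (0.01 log units; within the scatter). The methoxy compound stands apart, since methoxy in place of chloro gives a 2.5-fold lower number from compound 2 to compound 3 (0.40 log units; beyond the scatter) and methoxy in place of fluoro gives a 2.6-fold lower number from compound 1 to compound 3 (0.41 log units; beyond the scatter).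

Compound 4 `O=C(/C=C/c1ccc(O)c(O)c1)N1CCN(c2ccc([N+](=O)[O-])cc2)CC1` has not yet been measured. It carries 4-nitrophenyl in place of 2-chlorophenyl on an amine nitrogen in a ring. For the measured compounds named here, the measured steps bear on this change only loosely, as each exchanges one group on an aromatic carbon and no measured compound carries 4-nitrophenyl. Those steps run from within the scatter to modest, so a step of similar size at most is expected in this assay. No direction is clearly supported, and no shift beyond the scatter is expected. The estimated change is a 1.1-fold lower number from compound 2 to compound 4 (0.05 log units; within the scatter). For compound 4 the estimated value is 1.2 ug/mL, with an expected range of 0.45 ug/mL to 3.2 ug/mL.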

Compound 4, half-maximal inhibitory concentration: 1.14 ug/mL
For compound 4 the middle estimate is 1.1-fold (0.02 log units) above the measured one; low and high end bracket the measured number.
By their numbers in this assay, from the lowest: compound 3; then compounds 4, 2 and 1 (each within the scatter of the next).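

In this assay, 4-nitrophenyl in place of 2-chlorophenyl on the amine nitrogen in a ring stays within the scatter (a 1.2-fold lower number from compound 2 to compound 4 (0.08 log units; within the scatter)), and the same holds for the exchange with 2-fluorophenyl (a 1.2-fold lower number from compound 1 to compound 4 (0.08 log units; within the scatter)). For the compounds shown here, this is the first change that replaces the whole group on that nitrogen rather than one group on an aromatic carbon, and compound 4 lands with compound 1 and compound 2, so the position accepts a nitro-bearing phenyl without a step beyond the scatter. Going by these compounds alone, compound 3 goes against any reading that the group here makes no difference: it also stands apart from the new compound (a 2.1-fold higher number from compound 3 to compound 4 (0.32 log units; beyond the scatter)), and 2-methoxyphenyl is now the only group separated beyond the scatter from all the others. Nothing available accounts for these steps.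

The exchange alters both the group on the phenyl ring and where it sits, and the compounds shown cannot separate the two. As far as these compounds go, whether an amine or a carboxylic acid in place of the nitro group would stay with compound 4 or move towards compound 3 remains open.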